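Z to E Geometry on the Styryl Piperidine Core

This account rests on a few compounds, and the source may have more. Where it says the series, first, only, none or still open, it means among the compounds named here.

Compound 1 `CC(C)=CCN1CCCC(/C=C\c2ccccc2)C1` carries a 2-methylprop-1-en-1-yl group on the ring nitrogen and a Z-configured double bond toward the phenyl ring. In an assay on isolated protein for binding affinity to Sigma non-opioid intracellular receptor 1 (Rattus norvegicus) (on this read-out higher numbers stand for weaker inhibition and lower numbers for stronger inhibition), compound 1 gives 1 nM, the lowest of the three numbers recorded so far. Going by the values given here, compound 2 `C(=C\C1CCCN(CCC2CCCCC2)C1)\c1ccccc1` gives 7 nM in this assay, and the single change of cyclohexylmethyl in place of 2-methylprop-1-en-1-yl gives a 7.0-fold higher number from compound 1 to compound 2 (0.85 log units; beyond the scatter). Among the compounds with values here, compound 3 `O=C(CCCN1CCCC(/C=C\c2ccccc2)C1)c1ccccc1` gives 15 nM in this assay; it and compound 1 differ at the nitrogen substituent as well, and no single step between them is counted here.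

Compound 4 `CC(C)=CCN1CCCC(/C=C/c2ccccc2)C1` is the E-isomer of compound 1: the two compounds have the same atoms and bonds; at least one stereo element is drawn with a configuration in one of them and without one in the other: 1 of 2 stereo elements differ; a double bond is drawn Z in compound 1 and E in compound 4. Within the data shown here, none of the measured steps alters this double bond, so no measured step bears on the change. Without a precedent, the expected outcome for compound 4 is a step within the scatter or modestly in either direction, estimated as a 2.0-fold higher number from compound 1 to compound 4 (0.30 log units; within the scatter). Compound 4 is therefore expected to give about 2 nM in this assay, in a range from 0.5 nM to 8 nM.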

Compound 4, half-maximal inhibitory concentration: 38 nM
The estimate for compound 4 lay 19-fold (1.28 log units) below the measured number; measured number outside the range, above it.
By their numbers in this assay, from the lowest: compound 1; then compound 2; then compound 3; then compound 4.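

The switch of the double bond from Z to E leaves every atom and bond in place, yet in this assay it gives a 38-fold higher number from compound 1 to compound 4 (1.58 log units; beyond the scatter), a larger step than the one seen at the nitrogen substituent, a 7.0-fold higher number from compound 1 to compound 2 (0.85 log units; beyond the scatter). The earlier step left this double bond unchanged, so only now does its geometry emerge as a strong determinant of the read-out on the core of compound 1. The pair differs at this one place, and one feature of how the structures are drawn qualifies the reading: the fact that one of compounds 1 and 4 is drawn with a defined configuration and the other without, at the place where they differ.

The compounds shown leave open whether the same change has a step of similar size with the nitrogen substituent of compound 2 or compound 3. They also leave open how an alkyne in place of the double bond would read in this assay.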